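The source may hold more compounds than are shown below. What is called first, only, known or untested is meant among the compounds shown, and "the series" means these compounds.

Three compounds have been measured in an ADME assay on MT4 cells (Homo sapiens) for cytotoxicity, read by MTT assay, with a stated time of 4 days; a lower number here means that less compound is tolerated, a higher number that more compound is tolerated:

- compound 1, `Nc1ccc2oc(-c3ccc(F)cc3)cc(=O)c2c1`, gives 264000 nM
- compound 2, `Nc1ccc2oc(-c3ccc(C(F)(F)F)cc3)cc(=O)c2c1`, gives 273000 nM
- compound 3, `Nc1ccc2oc(-c3cccc(F)c3)c(O)c(=O)c2c1`, gives 35300 nM

Compound 1 and compound 2 share one core and differ by a single change, (trifluoromethyl in place of fluoro on an aromatic carbon). In this assay this change made a 1.0-fold higher number from compound 1 to compound 2 (0.01 log units; within the scatter), so the two compounds cannot be told apart on this read-out. Compound 3 is built on a different core; the difference between the two cores is not broken down here. What the values show is that compound 3 sits lowest of the three, with compound 1 and compound 2 both well beyond the scatter from it.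

Compound 4, `Nc1ccc2oc(-c3cccc(C(F)(F)F)c3)c(O)c(=O)c2c1`, has not yet been measured. Within the data shown here, it is made from compound 3 by trifluoromethyl in place of fluoro on an aromatic carbon, the same kind of change as the one from compound 1 to compound 2, the difference being that in compound 2 the trifluoromethyl stands para to a large group while in compound 4 it stands meta to a large group. Since the change from compound 1 to compound 2 gave a 1.0-fold higher number from compound 1 to compound 2 (0.01 log units; within the scatter), the step from compound 3 to compound 4 in this assay is expected to be small as well, about a 1.1-fold higher number from compound 3 to compound 4 (0.03 log units; within the scatter), and this rests on a single measured pair. Compound 4 is therefore estimated at 38000 nM in this assay, with a likely range from 19000 nM to 76000 nM.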

Compound 4, half-maximal cytotoxic concentration: 8100 nM
For compound 4 the middle estimate is 4.7-fold (0.67 log units) above the measured one; the measured number lies below the stated range.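

Replacing fluoro with trifluoromethyl on an aromatic carbon gives a 4.4-fold lower number from compound 3 to compound 4 (0.64 log units; beyond the scatter) in this assay, so on the core of compound 3 the swap is a real step towards less compound being tolerated. On the core of compound 1, the same kind of swap gave a 1.0-fold higher number from compound 1 to compound 2 (0.01 log units; within the scatter), which means that the result from one core cannot simply be carried over to the other in this series, as the two steps show: the same change on two cores in this assay, a 1.0-fold higher number (0.01 log units; within the scatter) from compound 1 to compound 2 and a 4.4-fold lower number (0.64 log units; beyond the scatter) from compound 3 to compound 4, 4.5-fold (0.65 log units) apart, beyond the scatter of two such steps. Among these compounds, this does not show why the steps differ: there is only one pair on each core, and the two pairs differ both in their core and in where the new group stands on the ring, so these data cannot separate those two influences or say how a third core would respond.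

The compounds shown leave open whether the two cores would still part ways if the swap were made at the same place on the ring in both. They also leave open how a chloro, a methyl or a nitrile in place of the fluoro would fare on the core of compound 3, since only fluoro and trifluoromethyl appear here.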